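Methylsulfonyl in Place of Methylsulfanyl: Compound 4

The source may hold more compounds than are shown below. What is called first, only, known or untested is meant among the compounds shown, and "the series" means these compounds.

Compound 1, `COc1ccc(S(C)(=O)=O)c(NCC2=NCCN2)c1`, gives 102% in a functional assay for agonist activity at Alpha-1A adrenergic receptor (Homo sapiens); on this read-out higher numbers stand for larger maximal responses and lower numbers for smaller maximal responses.
Compound 2, `Cc1ccc(S(C)(=O)=O)c(NCC2=NCCN2)c1`, gives 98%.
Compound 3, `CSc1ccc(C(F)(F)F)cc1NCC1=NCCN1`, gives 111%.

Of the three numbers, compound 3 stands highest; compound 1 lies within the usual scatter of it, while compound 2 lies beyond that scatter. Compound 4, `CS(=O)(=O)c1ccc(C(F)(F)F)cc1NCC1=NCCN1`, has not been measured yet. It differs from compound 3 in one place: methylsulfonyl in place of methylsulfanyl on an aromatic carbon. Within the data shown here, the only measured step between neighbours is a number 4 percentage points lower from compound 1 to compound 2 (within the scatter), a change of a different kind at a different position, so it bears on the present change only in showing that a single substituent swap on the same core left the maximal response essentially unchanged. Nothing measured here speaks directly to methylsulfonyl against methylsulfanyl. On this basis no step beyond the scatter is expected in this assay in either direction; the step from compound 3 to compound 4 is estimated as a number 6 percentage points lower from compound 3 to compound 4 (within the scatter). Compound 4 is therefore expected to give about 105%, between 90% and 120%.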

Compound 4, largest response reached (reported as maximum), in percent of the reference or control that the assay uses: 95%
Estimate against measurement, compound 4: 10 percentage points above; measured number inside the range.
By their numbers in this assay, from the lowest: compounds 4, 2, 1 and 3 (each within the scatter of the next, the first and the last beyond it).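

In this assay, methylsulfonyl in place of methylsulfanyl on this aromatic carbon, ortho to a group of 7 heavy atoms and para to a trifluoromethyl group, gives a number 16 percentage points lower from compound 3 to compound 4 (beyond the scatter) and so is the only single change shown that moves the maximal response beyond the usual scatter. With methylsulfonyl held in that place, the para group matters far less: trifluoromethyl in place of methyl gives a number 3 percentage points lower from compound 2 to compound 4 (within the scatter) and trifluoromethyl in place of methoxy gives a number 7 percentage points lower from compound 1 to compound 4 (within the scatter), so these three para groups cannot be told apart on this read-out. The data offer no measurement that accounts for the step at the sulfur-bearing position.

Methylsulfanyl appears here only with trifluoromethyl para to it, so it stays open whether the same step would appear with methyl or methoxy in that place. Also open, as far as these compounds go, is how a methylsulfinyl group, an ethylsulfonyl group or an amine on the same aromatic carbon would compare with the methylsulfanyl and methylsulfonyl groups.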